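The compounds below may be only part of what the source reports. "The series", "measured", "known", "first", "only" and "open" are said of these compounds alone.

Compound 1, with the structure `CCCCCCCCCO[C@@H]1[C@@H](N)[C@@H](OC[C@H](O)CN=[N+]=[N-])O[C@H](CN)[C@H]1OCCCCCCCCC`, is the stronger of the two measured compounds in a toxicity assay on the whole organism (J774 cells) for cytotoxicity, with Mus musculus as the target, read by MTT assay, with a stated time of 24 h, tested at 30 uM; a lower number here means a stronger effect, a higher number a weaker effect of the compound at the concentration tested: compound 1 gives 5.9%, the lowest of the two numbers. Compound 2, with the structure `NC[C@H]1O[C@H](O[C@H]2[C@H](OCCCc3ccc4ccccc4c3)[C@@H](O)[C@H](N)C[C@@H]2N)[C@H](N)[C@@H](OCCCc2ccc3ccccc3c2)[C@@H]1O`, stands far from it in this assay, where compound 2 gives 89.5%, a gap well beyond the usual scatter. Among the compounds with values here, no single-point step between measured compounds is available, so no measured change can be read directly. Compound 3, with the structure `CCCCCCCCCO[C@@H]1[C@@H](N)[C@@H](O[C@H]2[C@H](O)[C@@H](O)[C@H](N)C[C@@H]2N)O[C@H](CN)[C@H]1OCCCCCCCCC`, has not yet been tested. It differs from compound 1 in one place: 4,6-diamino-2,3-dihydroxycyclohexyl in place of 3-azido-2-hydroxypropyl on an oxygen on a saturated carbon. Within the data shown here, with only two measured numbers and no matching change to compare with, the expected step from compound 1 to compound 3 in this assay is uncertain; a move toward a higher number, that is a weaker effect, is expected, and the estimated step is a number 34.1 percentage points higher from compound 1 to compound 3 (beyond the scatter). For compound 3 the expected value in this assay is 40%, with a range from 5% to 90%.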

Compound 3, a percentage reported as activity, at one concentration (the size of the read-out at that concentration, not a potency): 48.6%
For compound 3 the middle estimate is 8.6 percentage points below the measured one, within the range that was stated.
By their numbers in this assay, from the lowest: compound 1; then compound 3; then compound 2.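

In this assay, putting 4,6-diamino-2,3-dihydroxycyclohexyl in place of 3-azido-2-hydroxypropyl on an oxygen on a saturated carbon gives a number 42.7 percentage points higher from compound 1 to compound 3 (beyond the scatter) and so a much weaker effect at the concentration tested. Within the data shown here, this is the first measured change at this position, and it shows that the group on this oxygen alone can shift the read-out by a large step while the rest of the molecule stays the same. Nothing available explains this step.

The compounds shown leave open whether the step follows the loss of the azide or the arrival of the ring with its amino and hydroxyl groups. A 3-amino-2-hydroxypropyl group or a plain cyclohexyl on the same oxygen would help to separate these two parts of the change.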